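A few compounds are considered here, and "the series" means these few. Any claim that something is new, unique, unknown or untested is made for them only; others in the source may bear on it.

Measured so far in a functional assay on MRC5 cells (Homo sapiens); on this read-out lower numbers stand for higher toxicity in this test and higher numbers for lower toxicity in this test:
compound 1 `O=C1c2ccccc2N(Cc2ccc(Cl)cc2)S(=O)(=O)N1Cc1ccc(Cl)cc1` gives 56000 nM;
compound 2 `O=C1c2ccccc2N(Cc2ccccc2)S(=O)(=O)N1Cc1ccc(Cl)cc1` gives 60000 nM;
compound 3 `O=C1c2ccccc2N(Cc2cccc(Cl)c2)S(=O)(=O)N1Cc1ccccc1` gives 60000 nM.

Compound 1 differs from compound 2 by chloro in place of hydrogen on an aromatic carbon, and that change gave a 1.1-fold lower number from compound 2 to compound 1 (0.03 log units; within the scatter) in this assay. Compound 2 and compound 3 have the same atoms joined differently; the difference between their two cores is not broken down here, and their values stand level.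

Compound 4 `O=C1c2ccccc2N(Cc2ccc(Cl)c(Cl)c2)S(=O)(=O)N1Cc1ccccc1` differs from compound 3 by chloro in place of hydrogen on an aromatic carbon. This is the same kind of change as from compound 2 to compound 1, but here the entering chloro sits ortho to a chloro group, which the earlier place did not have. The step from compound 3 to compound 4 in this assay is expected to be a 1.1-fold lower number from compound 3 to compound 4 (0.04 log units; within the scatter), resting on the earlier 1.1-fold lower number from compound 2 to compound 1 (0.03 log units; within the scatter). Compound 4 is therefore estimated at 55000 nM, from 30000 nM to 100000 nM.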

Compound 4, half-maximal cytotoxic concentration: 56000 nM
Beside the measured number, compound 4's estimate is 1.0-fold (0.01 log units) below it; the range from low to high includes it.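

In this assay, chloro in place of hydrogen on an aromatic carbon gave a 1.1-fold lower number from compound 3 to compound 4 (0.03 log units; within the scatter). Set beside the earlier case, the same change reads alike on the two cores: the same change on two cores in this assay, a 1.1-fold lower number (0.03 log units; within the scatter) from compound 2 to compound 1 and a 1.1-fold lower number (0.03 log units; within the scatter) from compound 3 to compound 4, 1.0-fold (0.00 log units) apart, within the scatter of two such steps. This shows that the change left the number within the scatter on both cores, including the place ortho to a chloro group, but two such small steps do not show that it would stay as small on any other core in this series.

The benzyl rings shown carry only chloro or hydrogen, so what an amine or a carboxylic acid would do there stays open. Also open, going by these compounds, is whether any change moves the number beyond the scatter.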